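The compounds below may be only part of what the source reports. "The series", "measured", "known", "first", "only" and "open" are said of these compounds alone.

In a functional assay on DU-145 cells (Homo sapiens) for inhibition, read by MTT assay, with a stated time of 72 h (a higher number here means a weaker inhibitor, a lower number a stronger inhibitor), compound 3 `O=C1C=C(N2CCC(c3ccccc3)CC2)C(=O)c2c(O)cccc21` gives 3000 nM. Compound 1 `O=C1C=C(N2CCN(c3ccccc3Cl)CC2)C(=O)c2c(O)cccc21` gives 2300 nM and compound 2 `O=C1C=C(N2CCC(c3ccccc3)CC2)C(=O)c2ccccc21` gives 6000 nM. Both lie within the usual scatter of compound 3, so these values do not separate it from either one. Compound 4 `O=C1C=C(N2CCC(c3ccc(Cl)cc3)CC2)C(=O)c2c(O)cccc21` differs from compound 3 by chloro in place of hydrogen on an aromatic carbon. Going by the values given here, no measured pair shows this change. Among the compounds with values here, the one measured step, a 2.0-fold lower number from compound 2 to compound 3 (0.30 log units; within the scatter), is a different change, hydroxy in place of hydrogen on an aromatic carbon. With only that to go on, no step beyond the scatter is expected in this assay. The expected step is a 1.2-fold lower number from compound 3 to compound 4 (0.08 log units; within the scatter). The estimated value for compound 4 is 2500 nM, with an expected range of 1000 nM to 6000 nM.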

Compound 4, half-maximal inhibitory concentration: 2600 nM
For compound 4 the middle estimate is 1.0-fold (0.02 log units) below the measured one; the measured number falls inside the stated range.
By their numbers in this assay, from the lowest: compounds 1, 4, 3 and 2 (each within the scatter of the next, the first and the last beyond it).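

In this assay, replacing phenyl with 4-chlorophenyl gives a 1.2-fold lower number from compound 3 to compound 4 (0.06 log units; within the scatter), so this single chlorine atom, placed para to a large group, leaves the result indistinguishable from that of the unsubstituted ring. The earlier step showed only a hydroxy change elsewhere on the molecule, whereas this one tests the phenyl ring itself. No available evidence explains this result. On these data alone, it remains open whether an amine or a carboxylic acid at this same position would shift the number, and whether chloro would behave alike without the core's hydroxy group.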